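A few compounds are considered here, and "the series" means these few. Any claim that something is new, unique, unknown or untested is made for them only; others in the source may bear on it.

Three compounds of the series have been run so far. Compound 1 `CC(C)NCCS(=O)(=O)NC(=O)c1ccc(Nc2nc(NC3(c4ccc(Cl)cc4)CC3)nc(OCC(F)(F)F)n2)cc1` and compound 3 `CCS(=O)(=O)NC(=O)c1ccc(Nc2nc(NC3(c4ccc(Cl)cc4)CC3)nc(OCC(F)(F)F)n2)cc1` share the same core and differ only in the tail of the sulfonylcarbamoyl side chain; compound 2 `CCCCCNc1nc(Nc2ccc([N+](=O)[O-])cc2)nc(OCC(F)(F)F)n1` keeps the triazine part but carries a pentylamino group and a nitro-substituted aniline. In an ADME assay on microsomes from liver (Rattus norvegicus) for metabolic stability, with a stated time of 10 min (a lower number here means that less of the compound is left, a higher number that more of the compound is left), compound 1 gives 100%, compound 3 gives 85% and compound 2 gives 35%. Compound 3 therefore stands second of the three numbers: compound 1 is its nearest neighbour, reached by the step of a number 15 percentage points lower from compound 1 to compound 3 (beyond the scatter), which is modest but beyond the scatter; compound 2 is the furthest away, well below it and beyond the scatter.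

Compound 4 `O=C(NS(=O)(=O)C1CC1)c1ccc(Nc2nc(NC3(c4ccc(Cl)cc4)CC3)nc(OCC(F)(F)F)n2)cc1` is the next candidate. It differs from compound 3 by cyclopropyl in place of ethyl on a sulfonyl sulfur. Within the data shown here, no measured pair alters the group on the sulfonyl sulfur itself; the single known step, a number 15 percentage points lower from compound 1 to compound 3 (beyond the scatter), removed a whole amino substituent further out on the chain and is a larger change in what is counted. With nothing bearing directly on an ethyl-to-cyclopropyl exchange, the step of no change at the digits printed from compound 3 to compound 4 (within the scatter) is expected to stay within the scatter. Compound 4 is estimated at 85% in this assay, with a range from 70% to 98%.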

Compound 4, percent of the compound remaining: 85%
Compound 4: the middle estimate sits on the measured number at the digits printed, and the stated range covers the measured number.
By their numbers in this assay, from the lowest: compound 2; then compounds 3 and 4 (each within the scatter of the next); then compound 1.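

In this assay the group on a sulfonyl sulfur whose other neighbour is an amide-type nitrogen is now exchanged directly, and cyclopropyl in place of ethyl gives no change at the digits printed from compound 3 to compound 4 (within the scatter) even though a three-membered ring of carbon only enters there. Cyclopropyl in place of 2-(isopropylamino)ethyl at the same place gives a number 15 percentage points lower from compound 1 to compound 4 (beyond the scatter) and so matches a number 15 percentage points lower from compound 1 to compound 3 (beyond the scatter) in size, which means that among these compounds the gap to compound 1 reads the same with either small carbon group on the sulfur. Nothing at hand accounts for either result.

From the compounds shown here alone, it remains open whether a larger group on the sulfonyl sulfur, such as phenyl or tert-butyl, would stay level with compound 3 and compound 4 or fall away from them. Compound 1 alone carries an amine in this tail, so the amine and the longer chain cannot be told apart as the feature that goes with its higher number, and a propyl or 2-hydroxyethyl group on the sulfur would bear on that question.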